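A Fluorine Added to the Benzoyl Ring of Compound 3

The source may hold more compounds than are shown below. What is called first, only, known or untested is meant among the compounds shown, and "the series" means these compounds.

Of the compounds shown here, three have been measured in a functional assay (aorta) with Rattus norvegicus as the target; a higher number here means a more potent compound, by a factor of ten per unit of this negative logarithm, a lower number a less potent compound. Compound 1 `CC1(C)C=C(n2ccccc2=O)c2cc(O)ccc2O1` gives 5.44, compound 2 `CC(=O)Oc1ccc2c(c1)C(n1ccccc1=O)=CC(C)(C)O2` gives 5.6 and compound 3 `CC1(C)C=C(n2ccccc2=O)c2cc(OCC(=O)c3ccccc3)ccc2O1` gives 5.05. Compound 3 stands lowest of the three: the step of a number 0.39 log units lower from compound 1 to compound 3 (beyond the scatter) and the step of a number 0.55 log units lower from compound 2 to compound 3 (beyond the scatter) both show that the benzoylmethyl group on the ring oxygen comes with a modest loss of potency, while the step of a number 0.16 log units higher from compound 1 to compound 2 (within the scatter) is only a small difference.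

Compound 4 `CC1(C)C=C(n2ccccc2=O)c2cc(OCC(=O)c3ccc(F)cc3)ccc2O1` keeps the benzoylmethyl group of compound 3 and adds a single atom to it: fluoro in place of hydrogen on an aromatic carbon. For the measured compounds named here, none of the measured steps introduces a fluoro group anywhere, so no measured step bears directly on this change; the two steps leading to compound 3 describe only the arrival of the larger group itself, and both were modest. With nothing pointing clearly in either direction, the expected step of no change at the digits printed from compound 3 to compound 4 (within the scatter) is small and within the usual scatter. Compound 4 is therefore estimated at 5.05, with a range from 4.6 to 5.5.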

Compound 4, logarithm of the reciprocal of the active concentration, log(1/C): 4.63
The estimate for compound 4 lay 0.42 log units above the measured number; the measured number falls inside the stated range.
By their numbers in this assay, from the lowest: compound 4; then compound 3; then compounds 1 and 2 (each within the scatter of the next).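

Until now the outer benzoyl ring had not been changed, and this result shows that it is not a silent place in this assay: a single fluoro on its aromatic carbon, para to a large group, gives a number 0.42 log units lower from compound 3 to compound 4 (beyond the scatter), a step of the same modest grade as those that came with the benzoylmethyl group itself. The loss carries through the series, so the ((4-fluorophenyl)carbonyl)methyl group gives a number 0.81 log units lower from compound 1 to compound 4 (beyond the scatter) when it replaces hydrogen and a number 0.97 log units lower from compound 2 to compound 4 (beyond the scatter) when it replaces acetyl. Nothing available explains why one atom at this place lowers the number.

From the compounds shown here alone, whether the loss belongs to fluoro alone or would follow any group on that carbon stays open. A methoxy group or an amine at the same place could begin to answer this.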